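The compounds below may be only part of what the source reports. "The series", "measured", "known", "first", "only" and "open" are said of these compounds alone.

Measured so far in a functional assay on HT-29 cells (Homo sapiens) for inhibition, with a stated time of 72 h; on this read-out higher numbers stand for weaker inhibition and lower numbers for stronger inhibition
compound 1 `COc1cc(C(=O)n2ccc3ccccc32)cc(OC)c1OC` gives 9600 nM
compound 2 `COc1cc(C(=O)c2ccc3cc[nH]c3c2)cc(OC)c1OC` gives 330 nM
compound 3 `CCn1ccc2cc(C(=O)c3cc(OC)c(OC)c(OC)c3)ccc21` gives 32 nM

Of these three, compound 3 has the lowest number and so the strongest inhibition in this assay. Its gaps to compound 2 and to compound 1 both lie beyond the usual scatter.

Compound 4 `COc1cc(C(=O)c2ccc3c(ccn3CCC(=O)O)c2)cc(OC)c1OC` is compound 3 with one change: carboxy in place of hydrogen on a saturated chain carbon, two bonds along the chain from an aromatic nitrogen. Put another way, ethyl becomes 2-carboxyethyl.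

Going by the values given here, no measured pair shows this change directly, so any expectation is loose. Compound 3, at 32 nM, already sits at the low end of the values seen, which leaves more room for the number to rise than to fall. The expected step of a 47-fold higher number from compound 3 to compound 4 (1.67 log units; beyond the scatter) is towards weaker inhibition and beyond the scatter. For compound 4 the estimate is 1500 nM with an expected range from 200 nM to 10000 nM in this measurement.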

Compound 4, half-maximal inhibitory concentration: > 10000 nM
Compound 4: no number, only a limit; the forecaster's own chance of this, stated with the estimate: 15%; middle value at least 6.6-fold (0.82 log units) from the limit.
By their numbers in this assay, from the lowest: compound 3; then compound 2; then compound 1. At a limit, above all of these: compound 4.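

In this assay, compound 4 gives a limit and not a number: the limit of > 10000 nM in this assay, at which 1 of the 4 values shown sits.

Even with only a limit, the step is large: an at least 310-fold higher number from compound 3 to compound 4 (2.49 log units; beyond the scatter). Going by these compounds alone, it is the first step here in which two measured compounds differ in one place, and it shows that this saturated chain on the aromatic nitrogen does not accept every change, as ethyl goes with strong inhibition and 2-carboxyethyl with far weaker inhibition.

As far as these compounds go, how far the true value of compound 4 lies past its limit remains open, so the full size of the step is unknown. The compounds shown also do not tell whether a methyl ester, an amine or a longer plain alkyl chain at this place would weaken inhibition as much as the carboxylic acid does.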